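Hydroxyethyl on the pyrimidinone ring with a dodecyl chain

The source may report more compounds than this note shows. Statements on the series, on what has been measured and on what is new or still open speak of the compounds shown alone.

Measured so far:
compound 1, `CCCCCCCCN(C)C(=O)Cn1cc(Cc2cnc(OCC)nc2)c(=O)nc1SCc1ccc(F)cc1`, 23%
compound 2, `CCCCCCCCCCCCN(C)C(=O)Cn1cc(Cc2cnc(O)nc2)c(=O)nc1SCc1ccc(F)cc1`, 83%
compound 3, `CCCCCCCCN(C)C(=O)Cn1cc(Cc2cnc(=O)n(CC(=O)O)c2)c(=O)nc1SCc1ccc(F)cc1`, 56%

In a functional assay on a cell-free system (plasma) for inhibition of platelet-activating factor acetylhydrolase (Homo sapiens), tested at 100 nM (on this read-out lower numbers stand for less inhibition and higher numbers for more inhibition at the one concentration tested (going by the name of the read-out)), compound 2 stands highest of the three numbers, beyond the scatter above both compound 3 and compound 1. Compound 4, `CCCCCCCCCCCCN(C)C(=O)Cn1cc(Cc2cnc(=O)n(CCO)c2)c(=O)nc1SCc1ccc(F)cc1`, has not yet been measured. It differs from compound 2 in one place: a group of 10 heavy atoms (6 carbon, 2 nitrogen, 2 oxygen; one six-membered aromatic ring with 2 hetero atoms) in place of a group of 7 heavy atoms (4 carbon, 2 nitrogen, 1 oxygen; one six-membered aromatic ring with 2 hetero atoms), on a saturated chain carbon bound to an aromatic carbon. Going by the values given here, the only single-point step measured so far, a number 33 percentage points higher from compound 1 to compound 3 (beyond the scatter), also replaces a ring group on the same chain carbon, but it starts from an ethoxy-bearing ring rather than a hydroxy-bearing one and sits on a shorter chain, so it does not match the present change directly. Compound 2 and compound 3 differ in two places at once, so their values alone cannot separate the ring change from the chain change. Among the compounds with values here, with no measured step that bears on this exact change, the expectation for compound 4 in this assay is a value near that of compound 2, with a number 5 percentage points lower from compound 2 to compound 4 (within the scatter) estimated to lie within the scatter. Compound 4 is therefore expected to give about 78%, in the range 58% to 95%.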

Compound 4, a percentage reported as inhibition, at one concentration (the size of the read-out at that concentration, not a potency): 77%
Compound 4: middle estimate off by 1 percentage points, on the high side, within the range that was stated.
By their numbers in this assay, from the lowest: compound 1; then compound 3; then compounds 4 and 2 (each within the scatter of the next).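

In this assay, the 2-hydroxypyrimidin-5-yl group on the saturated chain carbon bound to an aromatic carbon gives way to the larger hydroxyethyl-bearing ring group, with the dodecyl chain kept in both compounds, and the outcome is a number 6 percentage points lower from compound 2 to compound 4 (within the scatter). Going by these compounds alone, this is the first single change at this place measured on the dodecyl chain, and it shows that the ring group can take on the hydroxyethyl group with no shift beyond the usual scatter, which the earlier step on the shorter chain, starting from an ethoxy-bearing ring, could not show. The data shown offer no measurement that would explain this outcome.

The compounds shown leave open how an aminoethyl group in place of the hydroxyethyl group, or a chain longer than the dodecyl chain, would read at this position and at this concentration. They also leave open whether the hydroxyethyl-bearing ring group would behave the same way on the shorter chain of compound 1 and compound 3, since the two changes have not been separated on a single chain.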